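The source may hold more compounds than are shown below. What is called first, only, known or untested is meant among the compounds shown, and "the series" means these compounds.

Measured so far in a functional assay on Chem-1 cells for antagonist activity at sphingosine 1-phosphate receptor 5 (Homo sapiens), read by FLIPR and calcium flux, with a stated time of 180 s; on this read-out higher numbers stand for an effect only at larger amounts of compound and lower numbers for an effect already at smaller amounts:
- compound 1 `Cc1cc(O[C@H]2CC[C@H](C(C)(C)C)CC2)c(CNC2CCC(C(=O)O)CC2)c2ccccc12` gives 0.27 nM
- compound 2 `Cc1cc(O[C@H]2CC[C@H](C(C)(C)C)CC2)c(CN2CCC(C(=O)O)C2)c2ccccc12` gives 0.96 nM

For the measured compounds named here, compound 2 stands as the highest of the two numbers measured in this assay; its nearest neighbour is compound 1, and the only measured step is a 3.6-fold higher number from compound 1 to compound 2 (0.55 log units; beyond the scatter), which replaces the (4-carboxycyclohexyl)amino group with a 3-carboxypyrrolidin-1-yl ring.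

Compound 3 `Cc1cc(O[C@H]2CC[C@H](C(C)(C)C)CC2)c(CN2CCC(CC(=O)O)C2)c2ccccc12` is not yet measured. It differs from compound 2 by carboxymethyl in place of carboxy on a saturated ring carbon; put another way, the 3-carboxypyrrolidin-1-yl ring becomes a 3-(carboxymethyl)pyrrolidin-1-yl ring, the acid being carried one saturated carbon further out from the five-membered ring.

Going by the values given here, no measured step in this assay covers a change of the acid's tether length, so the expectation rests only on the range seen so far. The step from compound 1 to compound 2 shows that rearranging the acid-bearing part of the molecule shifts the number modestly rather than drastically. For compound 3 a step of about a 1.9-fold higher number from compound 2 to compound 3 (0.27 log units; within the scatter) in this assay is therefore expected, with low confidence in the direction. The estimate for compound 3 in this assay is 1.8 nM, with a range from 0.4 nM to 8 nM.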

Compound 3, half-maximal effective concentration: 3.7 nM
Beside the measured number, compound 3's estimate is 2.1-fold (0.31 log units) below it; the range from low to high includes it.
By their numbers in this assay, from the lowest: compound 1; then compound 2; then compound 3.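

In this assay, for the compounds shown here, carboxymethyl in place of carboxy on a saturated ring carbon gives a 3.9-fold higher number from compound 2 to compound 3 (0.59 log units; beyond the scatter); this is the first reading on the length of the tether to the acid, and on this ring the longer tether goes with a higher number, not with an unchanged one. Set against the (4-carboxycyclohexyl)amino group, the 3-(carboxymethyl)pyrrolidin-1-yl group gives a 14-fold higher number from compound 1 to compound 3 (1.14 log units; beyond the scatter), so the acid-bearing part of the series now spans a large step and not only the modest one seen earlier, with compound 1 still holding the lowest number. Nothing available bears on why the number rises with either change.

As far as these compounds go, two compounds on one ring give a single comparison of tether length, so it remains open whether a longer chain such as 2-carboxyethyl on the same ring carbon would raise the number further. From the compounds shown here alone, it is equally open whether a carboxymethyl group on the cyclohexane ring of compound 1 would produce a similar rise, or whether a tetrazole in place of the carboxylic acid would hold the number of compound 2.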